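This account rests on a few compounds, and the source may have more. Where it says the series, first, only, none or still open, it means among the compounds named here.

Compound 2 `Cc1ccc(NC(=O)c2ccc(/N=N\c3c[nH]c4ccccc34)cc2)c(C)c1` carries a 2,4-dimethylphenyl group on the amide-type nitrogen of the shared core. In a functional assay on MCF7 cells (Homo sapiens) for inhibition, read by MTT assay, with a stated time of 72 h (a higher number here means a weaker inhibitor, a lower number a stronger inhibitor), compound 2 gives 87000 nM. Within the data shown here, its only measured neighbour is compound 1 `O=C(Nc1ccccc1Cl)c1ccc(/N=N\c2c[nH]c3ccccc23)cc1`, which carries a 2-chlorophenyl group at the same position; in this assay compound 1 gives 112000 nM, and the step of a 1.3-fold lower number from compound 1 to compound 2 (0.11 log units; within the scatter) lies within the scatter, so the two numbers cannot be put in order. Compound 3 `Cc1cccc(NC(=O)c2ccc(/N=N\c3c[nH]c4ccccc34)cc2)c1` has not yet been measured; the change from compound 2 is 3-methylphenyl in place of 2,4-dimethylphenyl on an amide-type nitrogen. Among the measured compounds shown here, the one measured step that bears on this change, a 1.3-fold lower number from compound 1 to compound 2 (0.11 log units; within the scatter), is likewise a swap of the aryl group on the amide-type nitrogen, and it did not move the number beyond the scatter. For the measured compounds named here, with only that step to go on, a further swap of the aryl group on this nitrogen is expected to leave this assay essentially unchanged, and the expected step of a 1.0-fold higher number from compound 2 to compound 3 (0.01 log units; within the scatter) is therefore small in either direction. For compound 3 the estimate in this assay is 90000 nM, with a range from 40000 nM to 200000 nM.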

Compound 3, half-maximal inhibitory concentration: 73400 nM
Beside the measured number, compound 3's estimate is 1.2-fold (0.09 log units) above it, within the range that was stated.
By their numbers in this assay, from the lowest: compounds 3, 2 and 1 (each within the scatter of the next).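

In this assay the change to 3-methylphenyl on the amide-type nitrogen gives a 1.2-fold lower number from compound 2 to compound 3 (0.07 log units; within the scatter) and the change from 2-chlorophenyl gives a 1.5-fold lower number from compound 1 to compound 3 (0.18 log units; within the scatter) so a third aryl group at this position again produces no step beyond the scatter. Where one pair could be read before, all three pairs among compound 1, compound 2 and compound 3 now lie within the scatter, and the three numbers cannot be put in order; at this position, the 2-chlorophenyl, 2,4-dimethylphenyl and 3-methylphenyl groups cannot be told apart in this read-out. No measurement at hand explains this flat result.

The compounds shown cover only chloro- and methyl-substituted phenyl groups on this nitrogen, so it remains open whether a phenyl ring carrying a carboxylic acid or an amine, or a longer alkyl chain in place of the aryl group, would move the number beyond the scatter. The shared core is the same in all three compounds, which leaves open how a change elsewhere in it would read in this assay and whether that would outweigh anything seen at the amide-type nitrogen.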